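The source may report more compounds than this note shows. Statements on the series, on what has been measured and on what is new or still open speak of the compounds shown alone.

Measured so far in a functional assay on MV4-11 cells (Homo sapiens) for antiproliferative activity, read by luminescence and CellTiter-Glo, with a stated time of 72 h; on this read-out lower numbers stand for stronger inhibition and higher numbers for weaker inhibition:

Compound 1 `Cc1noc(C)c1-c1ccc(-n2ncc3ccc(-c4c(C)noc4C)cc32)c(Cl)c1`: 2800 nM
Compound 2 `Cc1ccc(Cn2nc(Nc3ccc(F)cc3)c3ccc(-c4c(C)noc4C)cc32)cc1`: "not determined" (no result reported)
Compound 3 `CNc1cc(-c2ccc3cnn(Cc4ccc(F)cc4)c3c2)cn(C)c1=O`: 2390 nM

Within the data shown here, only two of these three compounds carry a number in this assay. Compound 3, at 2390 nM, lies within the usual scatter of compound 1, at 2800 nM, so the two cannot be ranked, and compound 2 offers no comparison.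

The next compound is compound 4 `CNc1cc(-c2ccc3cnn(Cc4ccc(OC)cc4)c3c2)cn(C)c1=O`, which keeps the whole of compound 3 except for one substituent. A methoxy stands in place of the fluoro on an aromatic carbon, turning the 4-fluorobenzyl into a 4-methoxybenzyl: methoxy in place of fluoro on an aromatic carbon. Among the measured compounds shown here, no measured pair in this small set shows this change or any other single change, so the sole anchor is compound 3 at 2390 nM. With nothing to indicate a direction, no shift beyond the scatter is expected in this assay. The expected step is a 1.0-fold higher number from compound 3 to compound 4 (0.02 log units; within the scatter). For compound 4 the estimated value is 2500 nM, with an expected range of 900 nM to 7000 nM.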

Compound 4, half-maximal inhibitory concentration: 2700 nM
Compound 4: the middle estimate sits 1.1-fold (0.03 log units) below what was measured; measured number inside the range.
By their numbers in this assay, from the lowest: compounds 3, 4 and 1 (each within the scatter of the next).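

Among these compounds, the pair gives the first single-change comparison in this set. In this assay, methoxy in place of fluoro gives a 1.1-fold higher number from compound 3 to compound 4 (0.05 log units; within the scatter) and so leaves the number within the scatter. At this place, on an aromatic carbon para to a large group, the step from 4-fluorobenzyl to 4-methoxybenzyl adds a hydrogen-bond acceptor and one heavy atom, yet no separation between the two compounds can be read from the assay.

Going by these compounds, whether an amine, a carboxylic acid or a longer chain such as ethoxy at this place would shift the number beyond the scatter remains open. Also open is whether any group here can do so at all, and the data shown offer no measurement that would explain the result of this step.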